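The source may report more compounds than this note shows. Statements on the series, on what has been measured and on what is new or still open speak of the compounds shown alone.

Compound 1 `NC1=N[C@@]2(CO1)c1cc(-c3cncc(C#CC4CC4)c3)ccc1Oc1cnc(C3=CCOCC3)cc12`: 13 nm/s
Compound 2 `CC#Cc1cncc(-c2ccc3c(c2)[C@@]2(COC(N)=N2)c2cc(C4=CCCOC4)ncc2O3)c1`: 19 nm/s

Both numbers come from an ADME assay on LLC-PK1 cells (Sus scrofa) for permeability, read by LC-MS, with a stated time of 2 h, tested at 5 uM; a higher number here means that the compound crosses the layer faster, a lower number that the compound crosses the layer more slowly. Compound 1 gives 13 nm/s and compound 2 gives 19 nm/s. These two values lie within the usual scatter of each other, so compound 1 cannot be told apart from compound 2 on these numbers. Within the data shown here, the two compounds also differ in more than one place, so they offer no clean single-change step.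

Compound 3 `CC1(C#Cc2cncc(-c3ccc4c(c3)[C@@]3(COC(N)=N3)c3cc(C5=CCOCC5)ncc3O4)c2)COC1` has not yet been measured. It keeps the rest of compound 1 and changes one group: 3-methyloxetan-3-yl in place of cyclopropyl on a triple-bonded carbon. In words, 3-methyloxetan-3-yl stands in place of cyclopropyl on a triple-bonded carbon.

Among the measured compounds shown here, no measured pair shows this change, so its size in this assay has no direct precedent here. No step beyond the scatter is expected, in either direction. This expectation starts from compound 1 at 13 nm/s, the closest structure available. The estimated change is a 1.1-fold lower number from compound 1 to compound 3 (0.03 log units; within the scatter). For compound 3 the estimated value is 12 nm/s, with an expected range from 6 nm/s to 25 nm/s.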

Compound 3, apparent permeability: 18 nm/s
Compound 3: middle estimate off by 1.5-fold (0.18 log units), on the low side, and the stated range covers the measured number.
By their numbers in this assay, from the lowest: compounds 1, 3 and 2 (each within the scatter of the next).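

Among these compounds, the step from cyclopropyl to 3-methyloxetan-3-yl on a triple-bonded carbon is the first single-place comparison in this set, and in this assay it reads a 1.4-fold higher number from compound 1 to compound 3 (0.14 log units; within the scatter). At this place, then, a larger group whose ring holds an oxygen, which counts as a hydrogen-bond acceptor, can stand in for an all-carbon ring without a shift that this read-out can separate from ordinary repeat-to-repeat variation. No supporting measurement is available to explain this outcome, so the result describes what was seen but gives no reason for it.

Going by these compounds, whether an amine or a carboxylic acid on the same triple-bonded carbon would give a step beyond the scatter remains open, since both of the groups compared here are small uncharged rings. This is also a single pair on one shared core, so it cannot show whether the same exchange would give a similar step if the other groups on the molecule were different.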